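A few compounds are considered here, and "the series" means these few. Any claim that something is new, unique, unknown or untested is made for them only; others in the source may bear on it.

compound 1 `O=C(/C(=C\c1csc([N+](=O)[O-])c1)S(=O)(=O)c1ccc(Br)cc1)c1ccc(Br)cc1`: in a functional assay on DU-145 cells (Homo sapiens) for inhibition, read by trypan blue exclusion, with a stated time of 96 h (a higher number here means a weaker inhibitor of growth, a lower number a stronger inhibitor of growth), compound 1 gives 1000 nM
compound 2 `Nc1c(Br)cc(Br)cc1/C=C(\C(=O)c1ccc(Br)cc1)S(=O)(=O)c1ccc(Br)cc1`: in this assay compound 2 gives 25000 nM
compound 3 `COc1cc(C(=O)/C(=C\c2ccc([N+](=O)[O-])c(O)c2)SCc2ccc(Br)cc2)cc(OC)c1OC`: in this assay compound 3 gives 1000 nM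

Compound 2 stands highest of the three numbers; compound 1 and compound 3 both sit far lower, each beyond the scatter. Compound 4 `O=C(/C(=C\c1ccc(I)cc1)S(=O)(=O)c1ccc(Br)cc1)c1ccc(Br)cc1` is unmeasured. It differs from compound 2 as follows: 4-iodophenyl in place of 2-amino-3,5-dibromophenyl on a double-bonded chain carbon bound to a double-bonded chain carbon. Within the data shown here, the only measured step at this place is a 25-fold higher number from compound 1 to compound 2 (1.40 log units; beyond the scatter), a large rise that came with the 2-amino-3,5-dibromophenyl group now leaving. Removing that group is expected to undo much of that rise, though 4-iodophenyl is not the 5-nitrothiophen-3-yl of compound 1, so the full return is uncertain. A sizeable downward step is expected: a 13-fold lower number from compound 2 to compound 4 (1.10 log units; beyond the scatter). For compound 4 in this assay the estimate is 2000 nM, within 500 nM to 8000 nM.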

Compound 4, concentration for 50% growth inhibition: 1000 nM
Compound 4: the middle estimate sits 2.0-fold (0.30 log units) above what was measured; measured number inside the range.
By their numbers in this assay, from the lowest: compounds 1, 3 and 4 (each within the scatter of the next); then compound 2.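

In this assay, 4-iodophenyl in place of 2-amino-3,5-dibromophenyl gives a 25-fold lower number from compound 2 to compound 4 (1.40 log units; beyond the scatter), while 4-iodophenyl in place of 5-nitrothiophen-3-yl gives no change at the digits printed from compound 1 to compound 4 (within the scatter). The nitro group is therefore not required at this place to keep the lower number, and a benzene-type ring can serve as well as the thiophene, so the high number goes with 2-amino-3,5-dibromophenyl specifically. No available evidence explains this difference.

Still open, as far as these compounds go, is whether the amine, the bromines or both go with the high number. How an unsubstituted phenyl or a carboxylic acid on the ring would read at this place is also unknown.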